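From biphenyl ketone to furan ketone on a shared core

The source may report more compounds than this note shows. Statements on the series, on what has been measured and on what is new or still open speak of the compounds shown alone.

Of the compounds shown here, three sharing one core have been tested in a functional assay on HepG2 cells (Homo sapiens) for cytotoxicity, read by MTT assay, with a stated time of 48 h; on this read-out lower numbers stand for stronger inhibition and higher numbers for weaker inhibition. Compound 1 `COc1cc(-c2nnc3n2NC(c2ccco2)C(C(=O)c2ccccc2C)S3)cc(OC)c1OC` gives 63000 nM, and compound 2 `COc1cc(-c2nnc3n2NC(c2ccco2)C(C(=O)c2cccs2)S3)cc(OC)c1OC` gives 64100 nM; the step of a 1.0-fold higher number from compound 1 to compound 2 (0.01 log units; within the scatter) stays within the scatter. For compound 3 `COc1cc(-c2nnc3n2NC(c2ccco2)C(C(=O)c2ccc(-c4ccccc4)cc2)S3)cc(OC)c1OC` this assay returned only a limit, > 100000 nM, so compound 3 sits at the weak end of the numbers shown (the limit of > 100000 nM in this assay, at which 1 of the 3 values shown sits). The steps of an at least 1.5-fold higher number from compound 1 to compound 3 (0.20 log units; that floor lies within the scatter) and an at least 1.5-fold higher number from compound 2 to compound 3 (0.19 log units; that floor lies within the scatter) are therefore floors, not measured sizes. Compound 4 `COc1cc(-c2nnc3n2NC(c2ccco2)C(C(=O)c2ccco2)S3)cc(OC)c1OC` carries the change (furan-2-yl in place of 4-phenylphenyl on a carbonyl carbon), which reverses the kind of enlargement seen in those two steps. Compound 4 is therefore expected to resemble compound 2, whose value is 64100 nM. Compound 4 is estimated at 65000 nM, between 30000 nM and 140000 nM. The expected step is an at least 1.5-fold lower number from compound 3 to compound 4 (0.18 log units; that floor lies within the scatter).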

Compound 4, half-maximal inhibitory concentration: > 100000 nM
Compound 4 was reported as a limit; the forecaster's own chance of this, stated with the estimate: 25%; at least 1.5-fold (0.18 log units) between middle value and limit.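

In this assay compound 4 gives only a limit, so the smaller furan-2-yl on this carbonyl carbon ends at the same limit as the 4-phenylphenyl of compound 3: the limit of > 100000 nM in this assay, at which 2 of the 4 values shown sit. Against the other ketones only floors can be read (an at least 1.5-fold higher number from compound 2 to compound 4 (0.19 log units; that floor lies within the scatter); an at least 1.5-fold higher number from compound 1 to compound 4 (0.20 log units; that floor lies within the scatter)), so furan-2-yl need not truly differ from thiophen-2-yl or 2-methylphenyl. The step between the two limits cannot be read.

On these data alone, how far compound 3 and compound 4 really lie from each other stays open. So does what an amine or a longer alkyl chain would give on this carbonyl carbon.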